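The compounds below may be only part of what the source reports. "The series", "measured", "known", "first", "only" and "open" are said of these compounds alone.

Compounds measured so far:

Compound 1, `N/C(CC(O)c1cccc2ccccc12)=N\N=C\c1ccc(Cl)c(Cl)c1`, gives 16000 nM in an ADME assay on L6 cells (Rattus norvegicus) for cytotoxicity, read by resazurin assay, with a stated time of 72 h; on this read-out lower numbers stand for stronger inhibition and higher numbers for weaker inhibition.
Compound 2, `N/C(CC(O)c1cccc2ccccc12)=N\N=C\c1cccnc1`, gives 22000 nM in this assay.
Compound 3, `N/C(CC(O)c1cccc2ccccc12)=N\N=C\c1ccc(F)cc1F`, gives 4200 nM in this assay.

Compound 3 stands lowest of the three numbers in this assay: its nearest neighbour is compound 1, a 3.8-fold lower number from compound 1 to compound 3 (0.58 log units; beyond the scatter), and its furthest is compound 2, a 5.2-fold lower number from compound 2 to compound 3 (0.72 log units; beyond the scatter). Compounds 1 and 2 lie within the scatter of each other, a 1.4-fold higher number from compound 1 to compound 2 (0.14 log units; within the scatter).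

Compound 4, `N/C(CC(O)c1cccc2ccccc12)=N\N=C\c1ccco1`, has not yet been measured. It differs from compound 3 in one place: furan-2-yl in place of 2,4-difluorophenyl on a carbon with a double bond to nitrogen. Both measured steps that touch this position point the same way, with the 2,4-difluorophenyl giving the lowest number and the two other groups on that carbon giving clearly higher ones. A further exchange of that group in compound 4 is therefore expected to move the number back upward, a 2.9-fold higher number from compound 3 to compound 4 (0.46 log units; beyond the scatter), toward where compounds 1 and 2 stand. Compound 4 is expected to give about 12000 nM, within a range from 4000 nM to 35000 nM.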

Compound 4, half-maximal inhibitory concentration: 145000 nM
For compound 4 the middle estimate is 12-fold (1.08 log units) below the measured one, and the stated range ends below it.
By their numbers in this assay, from the lowest: compound 3; then compounds 1 and 2 (each within the scatter of the next); then compound 4.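

In this assay, for the compounds shown here, furan-2-yl in place of 2,4-difluorophenyl on a carbon with a double bond to nitrogen gives a 35-fold higher number from compound 3 to compound 4 (1.54 log units; beyond the scatter), a larger step than any among the earlier compounds, so this position spans a much wider range than those compounds showed. Furan-2-yl also stands apart from the other two groups, with a 6.6-fold higher number from compound 2 to compound 4 (0.82 log units; beyond the scatter) on replacing pyridin-3-yl and a 9.1-fold higher number from compound 1 to compound 4 (0.96 log units; beyond the scatter) on replacing 3,4-dichlorophenyl, which places compound 4 as the weakest inhibitor of the four on this read-out. Nothing available here accounts for the size of these steps.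

With only one five-membered ring among these groups, the compounds leave open whether this result goes with the ring size or with its oxygen. They also leave open whether a thiophen-2-yl or an unsubstituted phenyl on that carbon would stand nearer compound 3 or compound 4.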